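Replacing a Selenol by an Amino Group on the Shared Core

The source may hold more compounds than are shown below. What is called first, only, known or untested is meant among the compounds shown, and "the series" means these compounds.

In a functional assay on MCF7 cells (Homo sapiens) for cytotoxicity, read by MTT assay, with a stated time of 72 h (on this read-out higher numbers stand for lower toxicity in this test and lower numbers for higher toxicity in this test), three compounds built on one shared core were examined, and none reached a measurable number. Compound 1 `C[Se]c1nc(N)c2ccccc2n1` gives only a limit of > 100000 nM. Compound 2 `[SeH]c1nc([SeH])c2ccccc2n1` likewise gives only a limit of > 100000 nM. Compound 3 `COc1ccc(CNc2nc(SC)nc3ccccc23)cc1` also stops at a limit of > 100000 nM. Compound 2 thus stands exactly where every measured compound stands, at the limit of > 100000 nM in this assay, at which 3 of the 3 values shown sit.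

Compound 4 `Nc1nc([SeH])nc2ccccc12` differs from compound 2 in one place: one nitrogen atom in place of one selenium atom, on an aromatic carbon. Among the measured compounds shown here, no measured pair in this set differs by a single change, so no measured step gives the size of such an exchange. Compound 1, which also carries an amino group on the shared core, sits at its limit of > 100000 nM. The step from compound 2 to compound 4 is therefore expected to be a number no higher from compound 2 to compound 4 (the limit leaves the size open), none beyond the scatter. Compound 4 is expected to give 100000 nM, between 30000 nM and 300000 nM, most likely again only a limit.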

Compound 4, concentration lethal to 50% of the cells: > 100000 nM
Compound 4 ended at the assay's limit; the forecaster's own chance of this, stated with the estimate: 80%; the middle value sits exactly at the limit.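

Compound 4 gives only a limit, as compound 1 and compound 2 do, so neither step to compound 4 can be read: the limit of > 100000 nM in this assay, at which 4 of the 4 values shown sit.

The compounds shown leave open how large either exchange is and whether any of them would give a measurable number in this assay.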